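This account rests on a few compounds, and the source may have more. Where it says the series, first, only, none or still open, it means among the compounds named here.

Compound 1 `Cc1ccccc1N1CCN(CCCCOc2ccc3c(=O)cc(-c4ccccc4)oc3c2)CC1` — 19.5 nM
Compound 2 `Cc1ccccc1N1CCN(CCCCOc2ccc3c(=O)cc(-c4ccc(Cl)cc4)oc3c2)CC1` — 33.8 nM
Compound 3 `O=c1cc(-c2ccc(Cl)cc2)oc2cc(O)ccc12` — 143 nM

In a functional assay for antagonist activity at Adrenergic receptor alpha-1 (Rattus norvegicus) (on this read-out lower numbers stand for tighter binding and higher numbers for weaker binding), compound 3 gives the highest number of the three, with compound 2 the nearest and compound 1 the furthest from it. Compound 4 `O=c1cc(-c2ccc(Cl)cc2)oc2cc(OCCCCBr)ccc12` arises from compound 3 by 4-bromobutyl in place of hydrogen on an oxygen on an aromatic ring. For the measured compounds named here, the only measured step, a 1.7-fold higher number from compound 1 to compound 2 (0.24 log units; within the scatter), concerns a different position and does not bear on this change; no measured pair separates a bare hydroxy from an alkylated oxygen, although compounds 1 and 2, which carry a longer chain on that oxygen, show lower numbers than compound 3. The step from compound 3 to compound 4 is therefore estimated as a 1.0-fold higher number from compound 3 to compound 4 (0.02 log units; within the scatter), with no clear direction beyond the scatter. Compound 4 is expected to give about 150 nM, plausibly between 45 nM and 500 nM.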

Compound 4, dissociation constant: 429 nM
For compound 4 the middle estimate is 2.9-fold (0.46 log units) below the measured one; the measured number falls inside the stated range.
By their numbers in this assay, from the lowest: compounds 1 and 2 (each within the scatter of the next); then compound 3; then compound 4.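

In this assay the step to 4-bromobutyl on this oxygen gives a 3.0-fold higher number from compound 3 to compound 4 (0.48 log units; beyond the scatter) and is modest but beyond the scatter. For the compounds shown here, this is the first measured change at this oxygen, and it shows that the hydroxy hydrogen can be replaced with activity kept, while a chain there does not by itself lower the number. Nothing shown explains this rise. 

The compounds shown leave open whether the rise follows from the chain or from its bromine, which a plain butyl group could separate. On these data alone, how a methyl group or a shorter chain ending in an amine would fare at this oxygen also remains open.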